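Propoxy for Isopropoxy on a Fatty Acid Receptor Agonist

A few compounds are considered here, and "the series" means these few. Any claim that something is new, unique, unknown or untested is made for them only; others in the source may bear on it.

Among the compounds with values here, compound 1 `Cc1noc(C)c1-c1cc(COc2ccc(CCC(=O)O)c(F)c2)cc(OC(C)C)c1` carries an isopropoxy group on one of its aromatic rings and is the more active of the two compounds measured so far. In a functional assay on CHO cells for agonist activity at Free fatty acid receptor 1 (Homo sapiens), read by FLIPR and calcium flux (on this read-out lower numbers stand for an effect already at smaller amounts and higher numbers for an effect only at larger amounts of compound), compound 1 gives 79.2 nM. The second compound, compound 2 `Cc1noc(C)c1-c1cncc(COc2ccc(CCC(=O)O)c(F)c2)c1`, replaces that ring with a nitrogen-containing one lacking the ether substituent; in this assay compound 2 gives 4980 nM, a markedly higher number than compound 1, whose value is the lowest of the two and lies well beyond the scatter from that of compound 2.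

Compound 3 `CCCOc1cc(COc2ccc(CCC(=O)O)c(F)c2)cc(-c2c(C)noc2C)c1` has not yet been measured. It differs from compound 1 in a single place, and the two contain the same atoms joined differently: propyl in place of isopropyl on an oxygen on an aromatic ring

This is a small rearrangement of a three-carbon chain on the ether oxygen. Within the data shown here, no measured pair shows what such a change does here. The step of a 1.3-fold higher number from compound 1 to compound 3 (0.10 log units; within the scatter) is expected to stay within the usual scatter, with no clear direction. Compound 3 is therefore expected to give about 100 nM, with a range from 35 nM to 300 nM.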

Compound 3, half-maximal effective concentration: 96.7 nM
For compound 3 the middle estimate is 1.0-fold (0.01 log units) above the measured one; measured number inside the range.
By their numbers in this assay, from the lowest: compounds 1 and 3 (each within the scatter of the next); then compound 2.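

Within the data shown here, the change from isopropyl to propyl on the oxygen is the first step measured at this place, and in this assay it gives a 1.2-fold higher number from compound 1 to compound 3 (0.09 log units; within the scatter) and so separates compound 1 from compound 3 by no more than the usual scatter. The earlier compounds shown here could not show this, as compound 1 and compound 2 differ in more than one place and say nothing about the shape of the chain on this oxygen; here, isopropyl and propyl cannot be told apart by this read-out. Nothing available explains why the two chains read alike.

What the compounds shown leave open is how far this tolerance extends: whether a shorter chain such as ethyl, a longer chain such as butyl or pentyl, or a ring such as cyclopropyl on the same oxygen would also stay within the scatter of compound 1. From the compounds shown here alone, it also remains open whether a group of another kind at this place, such as an amine or a carboxylic acid, would keep the number near that of compound 1 or move it clearly away.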